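Swapping isopropyl for phenyl on an anilinic chain carbon

The source may hold more compounds than are shown below. What is called first, only, known or untested is meant among the compounds shown, and "the series" means these compounds.

Two compounds of this series carry measured numbers. Compound 1 `COc1ccc(N(Cc2ccccc2)CC(C)C)cc1` was tested in a functional assay on L929 cells (Mus musculus) for inhibition, read by MTT assay, with a stated time of 5 days (on this read-out lower numbers stand for stronger inhibition and higher numbers for weaker inhibition), where compound 1 gives 10 ug/mL. Compound 2 `Cc1ccc(N(CC(C)C)CC(C)C)cc1` was tested in the same way, and compound 2 gives 13 ug/mL. Compound 2 holds the highest of the two numbers, but its nearest neighbour, compound 1, sits only a little lower, and that gap lies within the scatter of the assay, so the two compounds cannot be told apart on these data.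

Compound 3 `Cc1ccc(N(Cc2ccccc2)CC(C)C)cc1` is the untested member. Relative to compound 2 it differs in one place: phenyl in place of isopropyl on a saturated chain carbon bound to a nitrogen on an aromatic ring. Going by the values given here, no measured pair in the set isolates this particular exchange, so there is nothing in the numbers to point toward a step of any size in either direction. With both measured compounds lying close together, the plain expectation is that compound 3 stays in the same region, and the step from compound 2 to compound 3 is estimated at a 1.2-fold lower number from compound 2 to compound 3 (0.07 log units; within the scatter), that is, nothing beyond the scatter. Compound 3 is therefore expected to give about 11 ug/mL in this assay, with a plausible range from 5 ug/mL to 25 ug/mL.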

Compound 3, half-maximal inhibitory concentration: 5 ug/mL
Compound 3: the middle estimate sits 2.2-fold (0.34 log units) above what was measured, within the range that was stated.
By their numbers in this assay, from the lowest: compounds 3, 1 and 2 (each within the scatter of the next, the first and the last beyond it).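

In this assay, the exchange of isopropyl for phenyl on a saturated chain carbon bound to a nitrogen on an aromatic ring now has a size of its own (a 2.6-fold lower number from compound 2 to compound 3 (0.41 log units; beyond the scatter)), a modest step and the only one here that lies beyond the scatter. The other new comparison, methyl in place of methoxy on an aromatic carbon (a 2.0-fold lower number from compound 1 to compound 3 (0.30 log units; within the scatter)), stays within the scatter, so with phenyl on the chain the two groups on the aromatic carbon cannot be told apart in this assay. Nothing in the data shown explains the size of either step.

The compounds shown leave open whether the gain is specific to phenyl, since they do not tell what a cyclohexyl group, a pyridine ring or a longer chain would give on the same chain carbon. They also leave open how an amine or a carboxylic acid carried on the entering phenyl would change the number, and whether the exchange gives a step of similar size when methoxy stands on the aromatic carbon instead of methyl.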